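The source may report more compounds than this note shows. Statements on the series, on what has been measured and on what is new or still open speak of the compounds shown alone.

Compound 1 `COc1ccc2nc(C)cc(OCC(=O)NCc3cc(C)cc(C)c3)c2c1` gives 5.25 in a physicochemical assay for lipophilicity, read by HPLC, in phosphate buffer, measured as chromatographic lipophilicity, at pH 7.4; a higher number here means a more lipophilic compound, a lower number a more polar compound.
Compound 2 `COc1ccc2nc(C)cc(OCC(=O)Nc3cc(C)ccc3OC)c2c1` gives 5.65 in this assay.
Compound 3 `COc1ccc2nc(C)cc(OCC(=O)Nc3ccc(Br)c(C)c3)c2c1` gives 5.95 in this assay.

Compound 3 has the highest of the three numbers in this assay; compound 2 is nearest to it, and the gap between them is within the scatter, while compound 1 is furthest, beyond the scatter. The steps that lead to compound 3 both go upward: a number 0.70 log units higher from compound 1 to compound 3 (beyond the scatter) and a number 0.30 log units higher from compound 2 to compound 3 (within the scatter).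

Compound 4 `COc1ccc2nc(C)cc(OCC(=O)Nc3c(C)cncc3C)c2c1` has not yet been measured in this assay. It differs from compound 3 in one place: 3,5-dimethylpyridin-4-yl in place of 4-bromo-3-methylphenyl on an amide-type nitrogen

Among the compounds with values here, none of the measured steps introduces a ring with a hetero atom or a hydrogen-bond acceptor on the group attached to the amide-type nitrogen, so they bear on this change only indirectly. Within the data shown here, what they show is that the bromine-bearing group of compound 3 gave the highest number, and that a group carrying only two methyl groups, as in compound 1, sits lowest. Since the entering group also carries two methyl groups and adds one hydrogen-bond acceptor while the bromine leaves, a step downward beyond the scatter is expected, estimated as a number 1.25 log units lower from compound 3 to compound 4 (beyond the scatter). Compound 4 is therefore estimated at 4.7, within a range from 4.1 to 5.3.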

Compound 4, distribution coefficient: 3.01
Estimate against measurement, compound 4: 1.69 log units above, and the stated range ends above it.
By their numbers in this assay, from the lowest: compound 4; then compound 1; then compounds 2 and 3 (each within the scatter of the next).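

At the group on the amide-type nitrogen, 3,5-dimethylpyridin-4-yl brings the largest moves yet seen in this assay: the number falls a number 2.94 log units lower from compound 3 to compound 4 (beyond the scatter) and a number 2.64 log units lower from compound 2 to compound 4 (beyond the scatter) and a number 2.24 log units lower from compound 1 to compound 4 (beyond the scatter) in the three readings of this change. Among the earlier compounds, each with an aromatic ring of carbon only at this place, the widest step was a number 0.70 log units higher from compound 1 to compound 3 (beyond the scatter) and so this position proved able to span a far wider range than they had shown, with compound 4 lying well apart from all three whichever one it is read against. No measurement here accounts for the size of the drop or separates the effect of the ring nitrogen from the departure of the bromine or the different placing of the methyl groups.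

The compounds shown leave open whether 2,6-dimethylphenyl on the same nitrogen, with carbon in place of the ring nitrogen, would give a number near compound 3 or near compound 4. They also leave open what pyridin-3-yl or pyridin-4-yl without its methyl groups would give at this place.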